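The source may hold more compounds than are shown below. What is called first, only, known or untested is meant among the compounds shown, and "the series" means these compounds.

In an assay on LX2 cells for inhibition of COL1A1 promoter (Homo sapiens), read by a luciferase reporter, with a stated time of 24 h, tested at 20 uM (a higher number here means a stronger effect of the compound at the concentration tested, a lower number a weaker effect), the three measured compounds give these numbers:

Compound 1 `Cc1ccc(-n2cc(C(=O)Nc3cc(F)cc(F)c3)c(=O)c3ccc(N(C)C)nc32)cc1OCCCCCCC[N+]12CCN(CC1)CC2` gives 5.07%.
Compound 2 `CN(C)c1ccc2c(=O)c(C(=O)Nc3cc(F)cc(F)c3)cn(-c3ccc(Cl)c(OCCCCCCC[N+]45CCN(CC4)CC5)c3)c2n1` gives 8.08%.
Compound 3 `Cc1ccc(-n2cc(C(=O)Nc3cc(F)cc(F)c3)c(=O)c3ccc(N(C)C)nc32)cc1OCCCCCCC[N+]1(C)CCCC1` gives 12.7%.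

Compound 3 sits at the top of these three numbers, yet the step of a number 7.6 percentage points higher from compound 1 to compound 3 (within the scatter) lies within the scatter, and the values of compound 2 and compound 3 are also within the scatter of each other, so no real ordering can be read from them. Compound 4 `CN(C)c1ccc2c(=O)c(C(=O)Nc3cc(F)cc(F)c3)cn(-c3ccc(Cl)c(OCCCCCCC[N+]4(C)CCCC4)c3)c2n1` is made from compound 3 by one change: chloro in place of methyl on an aromatic carbon. Among the measured compounds shown here, the one measured step that bears on this is a number 3 percentage points higher from compound 1 to compound 2 (within the scatter), the same exchange on a different partner, which stayed within the scatter. A similar outcome in this assay is therefore expected here. Compound 4 is estimated to give 15%, in the range 4% to 27%. The expected step is a number 2.3 percentage points higher from compound 3 to compound 4 (within the scatter).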

Compound 4, a percentage reported as inhibition, at one concentration (the size of the read-out at that concentration, not a potency): 51%
Estimate against measurement, compound 4: 36 percentage points below, outside the stated range (above it).
By their numbers in this assay, from the lowest: compounds 1, 2 and 3 (each within the scatter of the next); then compound 4.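

Chloro in place of methyl on this aromatic carbon does not add a fixed amount: with the five-membered ring on the chain it gives a number 38.3 percentage points higher from compound 3 to compound 4 (beyond the scatter), and the same exchange with the two six-membered rings on the chain behaves differently: the same change on two cores in this assay, a number 3 percentage points higher (within the scatter) from compound 1 to compound 2 and a number 38.3 percentage points higher (beyond the scatter) from compound 3 to compound 4, 35.3 percentage points apart, beyond the scatter of two such steps.
The ring exchange likewise depends on the aromatic substituent, since with chloro present it gives a number 42.9 percentage points higher from compound 2 to compound 4 (beyond the scatter), unlike with methyl: the same change on two cores in this assay, a number 7.6 percentage points higher (within the scatter) from compound 1 to compound 3 and a number 42.9 percentage points higher (beyond the scatter) from compound 2 to compound 4, 35.3 percentage points apart, beyond the scatter of two such steps.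
Among these compounds, the high number appears only where chloro and the five-membered ring occur together.

As far as these compounds go, whether bromo on the aromatic carbon or a shorter chain would keep this effect remains open.
A single tested concentration also gives no potency for compound 4.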